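A few compounds are considered here, and "the series" means these few. Any claim that something is new, unique, unknown or untested is made for them only; others in the source may bear on it.

Working notes on the shared core and its substituent at one aromatic carbon. Compound 1 `Cc1cc(-c2ccc(C=O)cc2)cn2c(CSCCc3ccccc3)cnc12` carries 4-formylphenyl there, compound 2 `Cc1cc(-c2ccco2)cn2c(CSCCc3ccccc3)cnc12` carries furan-2-yl, compound 3 `Cc1cc(N2CCCC2)cn2c(CSCCc3ccccc3)cnc12` carries pyrrolidin-1-yl, and the still unmeasured compound 4 `Cc1cc(N2CCN(C)CC2)cn2c(CSCCc3ccccc3)cnc12` carries 4-methylpiperazin-1-yl. In an ADME assay on HEL cells (Homo sapiens) for cytotoxicity, with a stated time of 3 days (a lower number here means that less compound is tolerated, a higher number that more compound is tolerated), compound 1 gives 100 ug/mL. For compound 2 the reading in this assay is > 4 ug/mL, which is a limit of the assay and not a number. In this assay, going by the values given here, compound 3 gives 20 ug/mL, the lowest of the two numbers known in the set; its nearest neighbour is compound 1, and the step is a 5.0-fold lower number from compound 1 to compound 3 (0.70 log units; beyond the scatter). The two steps that touch compound 2, a step that the limit leaves unreadable from compound 1 to compound 2 and a step that the limit leaves unreadable from compound 2 to compound 3, cannot be sized because of the limit of > 4 ug/mL in this assay, at which 1 of the 3 values shown sits.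

The change now followed is 4-methylpiperazin-1-yl in place of pyrrolidin-1-yl on an aromatic carbon. Among the compounds with values here, no measured step swaps one cyclic amine for another; the only readable step, a 5.0-fold lower number from compound 1 to compound 3 (0.70 log units; beyond the scatter), goes from an aryl group to a cyclic amine and is a different kind of change, so it offers little guidance. The step is therefore expected to stay within the scatter, a 1.3-fold higher number from compound 3 to compound 4 (0.10 log units; within the scatter), with no clear direction. Compound 4 is estimated at 25 ug/mL in this assay, with a range from 8 ug/mL to 80 ug/mL.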

Compound 4, minimum cytotoxic concentration: 20 ug/mL
Beside the measured number, compound 4's estimate is 1.3-fold (0.10 log units) above it; the range from low to high includes it.
By their numbers in this assay, from the lowest: compounds 3 and 4 (each within the scatter of the next); then compound 1.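

In this assay, the exchange of one cyclic amine for another at this aromatic carbon can now be read directly, and the result is no change at the digits printed from compound 3 to compound 4 (within the scatter), even though the entering 4-methylpiperazin-1-yl brings a six-membered ring with a second ring nitrogen in place of the five-membered ring of pyrrolidin-1-yl. The second cyclic amine also gives a 5.0-fold lower number from compound 1 to compound 4 (0.70 log units; beyond the scatter), which matches a 5.0-fold lower number from compound 1 to compound 3 (0.70 log units; beyond the scatter), so among compounds 1, 3 and 4 both cyclic amines stand apart from 4-formylphenyl by the same measure. Furan-2-yl in compound 2 cannot be set against either amine or against 4-formylphenyl, and every step that touches compound 2 stays unreadable, since its reading is a limit of the assay and not a number: the limit of > 4 ug/mL in this assay, at which 1 of the 4 values shown sits.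

Going by these compounds, whether the agreement between the two cyclic amines extends to a morpholin-4-yl ring or an open-chain dimethylamino group remains open. Also open, on these data alone, is whether the gap to compound 1 follows the amine nitrogen or the 4-formylphenyl group itself, a question that an unsubstituted phenyl group at this carbon could help to separate.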